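Working notes: substituent steps toward compound 4

The source may hold more compounds than are shown below. What is called first, only, known or untested is meant among the compounds shown, and "the series" means these compounds.

Measured in a functional assay on the whole organism for inhibition, with Mus musculus as the target, with a stated time of 1 h, at a dose of 100 mg/kg by the intraperitoneal route; a higher number here means more inhibition at the dose given (going by the name of the read-out), a lower number less inhibition:
compound 1 `Cc1nc2ccccc2c(=O)n1NC(=O)Nc1ccc(Cl)cc1` gives 48%
compound 2 `Cc1nc2ccccc2c(=O)n1NC(=O)Nc1ccc(I)cc1` gives 53%
compound 3 `COc1ccc(NC(=O)Nn2c(C)nc3ccccc3c2=O)cc1` gives 42%

Compound 3 stands lowest of the three numbers; compound 1 sits nearest to it and compound 2 furthest. The step of a number 6 percentage points lower from compound 1 to compound 3 (within the scatter) lies within the scatter, whereas a number 11 percentage points lower from compound 2 to compound 3 (beyond the scatter) lies beyond it. Compound 4 `Cc1nc2ccccc2c(=O)n1NC(=O)Nc1ccc([N+](=O)[O-])cc1` differs from compound 3 as follows: nitro in place of methoxy on an aromatic carbon. Within the data shown here, no measured step swaps methoxy for nitro; the two steps that bear on it replace chloro or iodo by methoxy, and both run downward, the iodo case modestly so. Moving away from methoxy is therefore expected to give no more than a modest rise in this assay, possibly none beyond the scatter. Compound 4 is expected to give 50%, between 36% and 64%, an expected step of a number 8 percentage points higher from compound 3 to compound 4 (within the scatter).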

Compound 4, a percentage reported as inhibition, in the whole organism at one dose (the size of the read-out at that dose, not a potency): 40%
Compound 4: middle estimate off by 10 percentage points, on the high side; measured number inside the range.
By their numbers in this assay, from the lowest: compounds 4, 3, 1 and 2 (each within the scatter of the next, the first and the last beyond it).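

Nitro, on an aromatic carbon para to a large group, brings no gain over methoxy in this assay, the step being a number 2 percentage points lower from compound 3 to compound 4 (within the scatter) in this swap. The swap from chloro gives a number 8 percentage points lower from compound 1 to compound 4 (within the scatter) and so also stays inside the scatter, while the swap from iodo gives a number 13 percentage points lower from compound 2 to compound 4 (beyond the scatter) and joins methoxy as a second group set apart from iodo. No supporting data offer a cause for this.

Still open, as far as these compounds go, is whether an amine or a carboxylic acid at this position would move the number beyond the scatter from compound 3 or compound 4.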